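Piperidinyl amide in place of pyrrolidinylmethyl amide

This account rests on a few compounds, and the source may have more. Where it says the series, first, only, none or still open, it means among the compounds named here.

Of the compounds shown here, three have been measured in a physicochemical assay for lipophilicity, measured as octanol-water partition, at pH 7.4; on this read-out lower numbers stand for lower lipophilicity and higher numbers for higher lipophilicity. Compound 1 (`Cc1ccc2[nH]c(C(=O)N[C@H]3CN(S(=O)(=O)c4ccnc(C)c4)C[C@@H]3C(=O)NCCN(C)C)cc2c1`) gives 1.7, compound 2 (`Cc1ccc2[nH]c(C(=O)N[C@H]3CCN(S(=O)(=O)c4cccnc4)C[C@@H]3C(=O)NCCN(C)C)cc2c1`) gives 1.3, and compound 3 (`Cc1ccc2[nH]c(C(=O)N[C@H]3CN(S(=O)(=O)c4ccccc4)C[C@@H]3C(=O)NC[C@H]3CCCN3)cc2c1`) gives 1. Compound 3 stands within the scatter of compound 2 and beyond the scatter below compound 1.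

Compound 4 (`Cc1ccc2[nH]c(C(=O)N[C@H]3CN(S(=O)(=O)c4ccccc4)C[C@@H]3C(=O)N[C@@H]3CCCNC3)cc2c1`) has the same atoms as compound 3, joined differently: piperidin-3-yl in place of (pyrrolidin-2-yl)methyl on an amide-type nitrogen. The change is piperidin-3-yl in place of (pyrrolidin-2-yl)methyl on an amide-type nitrogen. The leaving and entering groups match in heavy atoms, hydrogen-bond donors and hydrogen-bond acceptors. Among the compounds with values here, no measured pair differs in one place only, so no direct precedent exists for the size of this step. The closest reference is compound 3 at 1. The expected result in this assay is no change at the digits printed from compound 3 to compound 4 (within the scatter), with no change expected beyond the scatter. Compound 4 is estimated at 1, with an expected range of 0.6 to 1.4.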

Compound 4, distribution coefficient: 1.3
Compound 4: the middle estimate sits 0.30 log units below what was measured; the range from low to high includes it.
By their numbers in this assay, from the lowest: compounds 3, 2 and 4 (each within the scatter of the next); then compound 1.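

In this assay, within the data shown here, this is the first step that differs in one place: piperidin-3-yl in place of (pyrrolidin-2-yl)methyl on an amide-type nitrogen gives a number 0.30 log units higher from compound 3 to compound 4 (within the scatter). At this position, the two groups therefore cannot be told apart on this read-out, although one is a six-membered ring attached directly and the other a five-membered ring attached through a methyl link. No measurement available here bears on the reason for this result.

Among these compounds, whether the same swap reads alike with a sulfonyl group other than the one shared by compound 3 and compound 4 remains open, as compound 1 and compound 2 differ from them in more than one place. Also open, as far as these compounds go, is how a carboxylic acid or a longer chain carrying the ring amine would read on the same amide-type nitrogen.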